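This account rests on a few compounds, and the source may have more. Where it says the series, first, only, none or still open, it means among the compounds named here.

Working notes on the aryl sulfonate amides in a functional assay on HT-29 cells (Homo sapiens) for antiproliferative activity, read by sulforhodamine B assay, with a stated time of 48 h; a lower number here means a stronger inhibitor, a higher number a weaker inhibitor.

Compound 1 `CCCC(=O)Nc1cccc(S(=O)(=O)Oc2ccccc2C(C)C)c1` gives 13000 nM in this assay. Compound 2 `CCCCCC(=O)Nc1cccc(S(=O)(=O)Oc2ccccc2C(C)C)c1` gives 19000 nM in this assay. The change between them is ethyl in place of hydrogen on a saturated chain carbon, three bonds along the chain from a carbonyl carbon, and the measured step is a 1.5-fold higher number from compound 1 to compound 2 (0.16 log units; within the scatter); the two values therefore cannot be placed in any order.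

For the measured compounds named here, compound 3 `CCCC(=O)Nc1ccc(S(=O)(=O)Oc2ccccc2C(C)C)cc1` gives 4900 nM in this assay, the lowest of the three numbers so far; the gap to compound 1 and the gap to compound 2 are both beyond the scatter. Compound 3 and compound 1 share the same atoms joined differently; the difference between the two cores is not broken down here.

Compound 4 `CCCCCC(=O)Nc1ccc(S(=O)(=O)Oc2ccccc2C(C)C)cc1` is not yet measured in this assay. It differs from compound 3 by ethyl in place of hydrogen on a saturated chain carbon, three bonds along the chain from a carbonyl carbon, the same kind of change that separates compound 2 from compound 1, placed on the core of compound 3. Going by the values given here, the only guide to its size is the step from compound 1 to compound 2, which lay within the scatter. The expectation is that compound 4 behaves the same way on the core of compound 3, giving an estimated step of a 1.4-fold higher number from compound 3 to compound 4 (0.15 log units; within the scatter), because the earlier step of a 1.5-fold higher number from compound 1 to compound 2 (0.16 log units; within the scatter) was that small. Among the compounds with values here, on that basis compound 4 is estimated at 7000 nM in this assay, with an expected range from 3500 nM to 15000 nM; the range is wide because only one example of this change, a 1.5-fold higher number from compound 1 to compound 2 (0.16 log units; within the scatter), stands behind it.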

Compound 4, half-maximal inhibitory concentration: 6400 nM
Beside the measured number, compound 4's estimate is 1.1-fold (0.04 log units) above it; the measured number falls inside the stated range.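

In this assay, ethyl in place of hydrogen on a saturated chain carbon, three bonds along the chain from a carbonyl carbon, gives a 1.3-fold higher number from compound 3 to compound 4 (0.12 log units; within the scatter), so on this core too the two values cannot be placed in any order. Set beside the earlier step, the change carries from one core to the other with no difference that can be read: the same change on two cores in this assay, a 1.5-fold higher number (0.16 log units; within the scatter) from compound 1 to compound 2 and a 1.3-fold higher number (0.12 log units; within the scatter) from compound 3 to compound 4, 1.1-fold (0.05 log units) apart, within the scatter of two such steps. This shows that propyl to pentyl gives a step within the scatter on both cores shown, but two such steps do not show that the same would hold on any other core, and they say nothing about what lies behind the gap between the core of compound 1 and the core of compound 3.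

The compounds shown leave open whether a longer chain than pentyl, or a chain ending in an amine or a carboxylic acid, would give a step beyond the scatter at this place. Also open, as far as these compounds go, is whether a methyl in place of the propyl would give a step that can be read on either core.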